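Second chloro on the anilide ring: cytotoxicity outlook

This account rests on a few compounds, and the source may have more. Where it says the series, first, only, none or still open, it means among the compounds named here.

Compound 1 `Cn1cc(SCC(=O)Nc2ccccc2Cl)c2ccccc21` stands at a limit in an ADME assay on HEK-293T cells (Homo sapiens) for cytotoxicity, read by CCK-8 assay, with a stated time of 48 h; a higher number here means that more compound is tolerated, a lower number that less compound is tolerated: compound 1 gives > 100000 nM, which is a limit of the assay and not a number. Compound 3 `Cn1cc(SCC(=O)Nc2cccc(Cl)c2)c2ccccc21` sits at the same kind of limit, and in this assay compound 3 gives > 100000 nM. Among the compounds with values here, compound 2 `O=C(CSc1c[nH]c2cc(Cl)ccc12)Nc1ccc(Cl)c(Cl)c1` is the only member with a measured number; in this assay compound 2 gives 67800 nM. Compound 1 therefore sits at the limit of > 100000 nM in this assay, at which 2 of the 3 values shown sit. Within the data shown here, the only step between measured compounds that differ in one place is a step that the two limits leave unreadable from compound 1 to compound 3, and it yields no usable size.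

Compound 4 `Cn1cc(SCC(=O)Nc2c(Cl)cccc2Cl)c2ccccc21` differs from compound 1 by chloro in place of hydrogen on an aromatic carbon. Among the measured compounds shown here, no measured step bears directly on this change; compound 2 differs from compound 1 in more than one place, so only its value can be set beside it. With compound 1 already at the limit, the step of a number no higher from compound 1 to compound 4 (the limit leaves the size open) is estimated as none beyond the scatter. Compound 4 is expected to give 100000 nM, within 40000 nM to 200000 nM, most likely reported again as a limit.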

Compound 4, half-maximal cytotoxic concentration: > 100000 nM
Compound 4: only a limit was reported; the forecaster's own chance of this, stated with the estimate: 65%; the middle value lies on the limit itself.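

Compound 1 and compound 4 each stand at a limit of this assay, not at a number, so no step can be read between them: the limit of > 100000 nM in this assay, at which 3 of the 4 values shown sit.

The compounds shown leave open whether chloro in place of hydrogen on an aromatic carbon changes tolerance in this assay at all, and by how much.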